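Fluorine Added to the Aryl Ring of a Benzothiazole Urea

A few compounds are considered here, and "the series" means these few. Any claim that something is new, unique, unknown or untested is made for them only; others in the source may bear on it.

Compound 1 `O=C(Nc1ccc2sc(-c3ccccc3)nc2c1)N1CCCCC1`: > 50 uM
Compound 2 `O=C(Nc1ccc2sc(-c3ccc(F)cc3)nc2c1)N1CCCCC1`: > 50 uM
Compound 3 `O=C(Nc1ccc2sc(-c3cccc(F)c3)nc2c1)N1CCCC1`: > 50 uM

All three were tested in an ADME assay on HepG2 cells (Homo sapiens) for inhibition, read by resazurin assay, with a stated time of 48 h; on this read-out higher numbers stand for an effect only at larger amounts of compound and lower numbers for an effect already at smaller amounts. The value of compound 1 is a limit of the assay, not a number. The value of compound 2 is likewise a limit. The value of compound 3 is also a limit. Compound 1 and compound 2 differ by fluoro in place of hydrogen on an aromatic carbon, and this gives a step that the two limits leave unreadable from compound 1 to compound 2, because of the limit of > 50 uM in this assay, at which 3 of the 3 values shown sit. How the core of compound 1 differs from the core of compound 3 is not broken down here.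

Compound 4 `O=C(Nc1ccc2sc(-c3cccc(F)c3F)nc2c1)N1CCCC1` has not been measured in this assay. It differs from compound 3 by fluoro in place of hydrogen on an aromatic carbon. This is the same kind of change as from compound 1 to compound 2, though the place differs: there the fluoro sits para to a large group, here it sits ortho to a fluoro group and ortho to a large group. The step from compound 3 to compound 4 is expected to be a step that the limit leaves unreadable from compound 3 to compound 4, resting on compound 3 giving > 50 uM and on the unreadable a step that the two limits leave unreadable from compound 1 to compound 2. Compound 4 is therefore estimated at 70 uM, expected between 30 uM and 200 uM.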

Compound 4, concentration for 90% of the maximal effect: > 50 uM
Compound 4: a limit, no number (the forecaster's own chance of this, stated with the estimate: 80%); the middle value is on the limit's open side.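

The step from compound 3 to compound 4 cannot be read, because both values are limits of the assay and not numbers: the limit of > 50 uM in this assay, at which 4 of the 4 values shown sit. The compounds shown leave open at what concentration any of them would reach this effect, and whether the added fluoro shifts that concentration at all.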